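A few compounds are considered here, and "the series" means these few. Any claim that something is new, unique, unknown or untested is made for them only; others in the source may bear on it.

Measured compounds:
compound 1 `COc1cccc(-c2c(-c3ccccc3)c(-c3ccccc3)n3ccc(C#N)cc23)c1` — "not determined" (no result reported)
compound 2 `N#Cc1ccn2c(-c3ccccc3)c(-c3ccccc3)c(Cc3ccccc3)c2c1` — 46000 nM

Going by the values given here, in an assay for inhibition of Polyunsaturated fatty acid lipoxygenase ALOX15 (Oryctolagus cuniculus) (on this read-out higher numbers stand for weaker inhibition and lower numbers for stronger inhibition), compound 2 gives 46000 nM, which is the only number in this set and stands as weak inhibition. Compound 1 has no reported result. Compound 3 `N#Cc1ccn2c(-c3ccccc3)c(-c3ccccc3)c(OCOCc3ccccc3)c2c1` differs from compound 2 in one place: (benzyloxy)methoxy in place of benzyl on an aromatic carbon. Among the compounds with values here, no measured pair shows what such a change does here, so the step in this assay is expected to stay within the scatter, with no clear direction. Compound 3 is expected to give 40000 nM, in a range from 10000 nM to 160000 nM. The expected step is a 1.2-fold lower number from compound 2 to compound 3 (0.06 log units; within the scatter).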

Compound 3, half-maximal inhibitory concentration: 39000 nM
Beside the measured number, compound 3's estimate is 1.0-fold (0.01 log units) above it; the range from low to high includes it.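

In this assay the swap of benzyl for (benzyloxy)methoxy on this aromatic carbon of the five-membered ring is a 1.2-fold lower number from compound 2 to compound 3 (0.07 log units; within the scatter) and so lies within the scatter. This first measured pair shows that the read-out stays in the same range when this position takes the larger group, which brings 2 hydrogen-bond acceptors where benzyl has none. No evidence bears on why the number holds. Going by these compounds, whether an amine or a carboxylic acid on this carbon would move the number beyond the scatter stays open, as does the effect of a shorter group such as methoxy.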